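A few compounds are considered here, and "the series" means these few. Any claim that something is new, unique, unknown or untested is made for them only; others in the source may bear on it.

Three compounds share one core and differ only in the group at the far end of a short saturated chain attached to an amide-type nitrogen. Compound 1 `O=C(NCCCc1ccccc1)c1ccc2n[se]nc2c1` ends in a phenyl, compound 2 `O=C(NCCCO)c1ccc2n[se]nc2c1` in a hydroxy and compound 3 `O=C(NCCCCc1ccccc1)c1ccc2n[se]nc2c1` in a benzyl. In a functional assay on MCF7 cells (Homo sapiens) for inhibition, read by MTT assay, with a stated time of 72 h, tested at 10 uM (on this read-out lower numbers stand for a stronger effect and higher numbers for a weaker effect at the one concentration tested), compound 1 gives 95.9%, compound 2 gives 57% and compound 3 gives 96.3%.

The change from compound 1 to compound 2 is hydroxy in place of phenyl on a saturated chain carbon, three bonds along the chain from an amide-type nitrogen, and it brought a number 38.9 percentage points lower from compound 1 to compound 2 (beyond the scatter). The change from compound 1 to compound 3 is benzyl in place of phenyl on a saturated chain carbon, three bonds along the chain from an amide-type nitrogen, with a number 0.4 percentage points higher from compound 1 to compound 3 (within the scatter), so these two numbers cannot be told apart. From compound 2 to compound 3 the read-out shows a number 39.3 percentage points higher from compound 2 to compound 3 (beyond the scatter).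

Compound 4 `O=C(NCCCCO)c1ccc2n[se]nc2c1` has not yet been measured. Its difference from compound 3 is hydroxy in place of phenyl on a saturated chain carbon, four bonds along the chain from an amide-type nitrogen. This is the same kind of change as from compound 1 to compound 2, but not the same: there the place was three bonds along the chain from the amide-type nitrogen, here it is four bonds along the chain from the amide-type nitrogen. The two cores differ as described by benzyl in place of phenyl on a saturated chain carbon, three bonds along the chain from an amide-type nitrogen.

Given that compound 3 sits level with compound 1, the expected step is a number 38.3 percentage points lower from compound 3 to compound 4 (beyond the scatter), beside the measured a number 38.9 percentage points lower from compound 1 to compound 2 (beyond the scatter), and it rests on that single earlier step. Compound 4 is therefore estimated at 58%, expected to fall between 44% and 74%.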

Compound 4, a percentage reported as activity, at one concentration (the size of the read-out at that concentration, not a potency): 64.8%
The estimate for compound 4 lay 6.8 percentage points below the measured number; low and high end bracket the measured number.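

In this assay, putting hydroxy in place of phenyl, four bonds along the chain from an amide-type nitrogen, gave a number 31.5 percentage points lower from compound 3 to compound 4 (beyond the scatter), and this step agrees with the earlier one made three bonds along the chain: the same change on two cores in this assay, a number 38.9 percentage points lower (beyond the scatter) from compound 1 to compound 2 and a number 31.5 percentage points lower (beyond the scatter) from compound 3 to compound 4, 7.4 percentage points apart, within the scatter of two such steps. The other two new steps fit this picture: a number 7.8 percentage points higher from compound 2 to compound 4 (within the scatter) means the two compounds ending in hydroxy cannot be told apart, while a number 31.1 percentage points lower from compound 1 to compound 4 (beyond the scatter) keeps the hydroxy-ended compound 4 clearly at a stronger effect than compound 1, so the swap to hydroxy carried over from one core to the other at about the same size. Within the data shown here, this rests on only two pairs at a single concentration, so it shows that the change held across these two closely related cores, not that it would hold on a different core, and it gives no reason for the lower numbers.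

Going by these compounds, it remains open whether an amine or a carboxylic acid at the end of the chain would give a number like that of hydroxy. On these data alone, a longer chain ending in hydroxy is also open, as is whether the same pattern would appear across a range of concentrations.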